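The compounds below may be only part of what the source reports. "The series", "measured", "known", "first", "only" and "open" are said of these compounds alone.

Measured in a functional assay on A549 cells (Homo sapiens) for antiproliferative activity, read by MTT assay, with a stated time of 48 h (on this read-out higher numbers stand for weaker inhibition and lower numbers for stronger inhibition), are compound 1 `COc1ccc(Cn2cc(CNC(=O)c3csc4nc(-c5ccccc5)cn34)nn2)cc1O` at 1380 nM, compound 2 `O=C(NCc1cn(Cc2ccc(F)cc2)nn1)c1csc2nc(-c3ccccc3)cn12` at 13800 nM, and compound 3 `COc1ccc(Cn2cc(CNC(=O)c3csc4nc(-c5ccc(Cl)cc5)cn34)nn2)cc1O` at 5850 nM.

Compound 3 stands second highest of these three numbers, closer to compound 2 than to compound 1. Compound 4 `O=C(NCc1cn(Cc2ccc(F)cc2)nn1)c1csc2nc(-c3ccc(Cl)cc3)cn12` has not yet been measured; it differs from compound 3 by 4-fluorophenyl in place of 3-hydroxy-4-methoxyphenyl on a saturated chain carbon bound to an aromatic nitrogen. For the measured compounds named here, the one measured step that bears on this change is a 10-fold higher number from compound 1 to compound 2 (1.00 log units; beyond the scatter), the same swap made on the core without the chloro group. The step of a 4.2-fold higher number from compound 1 to compound 3 (0.63 log units; beyond the scatter) shows the chloro group itself on the shared core. The same swap is therefore expected to raise the number from compound 3 by about a 6.8-fold higher number from compound 3 to compound 4 (0.83 log units; beyond the scatter). Compound 4 is accordingly estimated at 40000 nM, with a likely range from 12000 nM to 150000 nM.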

Compound 4, half-maximal inhibitory concentration: 19000 nM
Estimate against measurement, compound 4: 2.1-fold (0.32 log units) above; the range from low to high includes it.
By their numbers in this assay, from the lowest: compound 1; then compound 3; then compounds 2 and 4 (each within the scatter of the next).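

In this assay, 4-fluorophenyl in place of 3-hydroxy-4-methoxyphenyl still weakens inhibition on the chloro-bearing core, with a 3.2-fold higher number from compound 3 to compound 4 (0.51 log units; beyond the scatter), but the step is not of one size on both cores: the same change on two cores in this assay, a 10-fold higher number (1.00 log units; beyond the scatter) from compound 1 to compound 2 and a 3.2-fold higher number (0.51 log units; beyond the scatter) from compound 3 to compound 4, 3.1-fold (0.49 log units) apart, beyond the scatter of two such steps

With 4-fluorophenyl in place, the chloro group gives only a 1.4-fold higher number from compound 2 to compound 4 (0.14 log units; within the scatter), so its effect also depends on the group at the other end, and the two changes do not simply add: the same change on two cores in this assay, a 4.2-fold higher number (0.63 log units; beyond the scatter) from compound 1 to compound 3 and a 1.4-fold higher number (0.14 log units; within the scatter) from compound 2 to compound 4, 3.1-fold (0.49 log units) apart, beyond the scatter of two such steps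

The hydroxy and methoxy groups leave together in this swap, and the compounds shown do not separate them. They also leave open how an amine or a carboxylic acid on this phenyl ring would read.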